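Replacing the Aziridine Ring on a Quinone Core

The compounds below may be only part of what the source reports. "The series", "measured", "known", "first", "only" and "open" are said of these compounds alone.

Compound 1 `O=C1C(N2CCCC2)=CC(=O)c2nc(-c3ccccc3)ccc21` gives 44700 nM in a functional assay on NCI60 cells (Homo sapiens) for cytotoxicity; on this read-out lower numbers stand for stronger inhibition of growth and higher numbers for weaker inhibition of growth; compound 2 `O=C1C(N2CC2)=CC(=O)c2nc(-c3ccccc3)ccc21` gives 27.5 nM in this assay.

Of these two, compound 2 has the lowest number, with compound 1 far higher. For the measured compounds named here, the only measured step, a 1600-fold lower number from compound 1 to compound 2 (3.21 log units; beyond the scatter), came with aziridin-1-yl replacing pyrrolidin-1-yl. Compound 3 `O=C1C(NCc2ccccc2)=CC(=O)c2nc(-c3ccccc3)ccc21` carries the change (benzylamino in place of aziridin-1-yl on a double-bonded ring carbon). The three-membered ring that accompanied the large drop is gone again, so a large rise in number is expected, toward the value of compound 1. For compound 3 the estimate in this assay is 20000 nM, between 3000 nM and 80000 nM, an expected step of a 730-fold higher number from compound 2 to compound 3 (2.86 log units; beyond the scatter).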

Compound 3, concentration for 50% growth inhibition: 1700 nM
The estimate for compound 3 lay 12-fold (1.07 log units) above the measured number; measured number outside the range, below it.
By their numbers in this assay, from the lowest: compound 2; then compound 3; then compound 1.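

Swapping aziridin-1-yl for benzylamino in this assay brings a 62-fold higher number from compound 2 to compound 3 (1.79 log units; beyond the scatter) and yet swapping pyrrolidin-1-yl for benzylamino brings a 26-fold lower number from compound 1 to compound 3 (1.42 log units; beyond the scatter) as well. Growth inhibition at this double-bonded ring carbon therefore does not stand or fall with the three-membered ring alone: the two groups without that ring also differ widely from each other. Nothing measured here gives a reason for these steps.

Going by these compounds, whether the benzene ring of benzylamino or its amine hydrogen goes with the lower number than compound 1 stays open. A methylamino group would help to separate the two, and an azetidin-1-yl group would show how a four-membered ring compares.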